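The source may report more compounds than this note shows. Statements on the series, on what has been measured and on what is new or still open speak of the compounds shown alone.

Compound 1 `C/N=C(/NC#N)NCCCCCn1nc(-c2ccccc2)c(C)cc1=O` gives > 100 mg/kg in a functional assay on the whole organism (stomach) with Rattus norvegicus as the target (on this read-out lower numbers stand for an effect already at smaller amounts and higher numbers for an effect only at larger amounts of compound), which is a limit of the assay and not a number. Compound 2 `C/N=C(/NC#N)NCCCCn1nc(-c2ccccc2)c(C)cc1=O` gives > 100 mg/kg in this assay, again a limit of the assay. Compound 3 `C/N=C(/NC#N)NCCCCn1nc(-c2ccccc2)cc(C)c1=O` gives 60.8 mg/kg in this assay.

Compound 1 and compound 2 differ by a group of 7 heavy atoms (3 carbon, 4 nitrogen; no ring) in place of a group of 8 heavy atoms (4 carbon, 4 nitrogen; no ring), on a saturated chain carbon, four bonds along the chain from an aromatic nitrogen. The step that the two limits leave unreadable from compound 1 to compound 2 cannot be read, since both values sit at the limit of > 100 mg/kg in this assay, at which 2 of the 3 values shown sit. The difference between the core of compound 1 and the core of compound 3 is not broken down here. Compound 4 `C/N=C(/NC#N)NCCCn1nc(-c2ccccc2)cc(C)c1=O` is unmeasured and differs from compound 3 by a group of 7 heavy atoms (3 carbon, 4 nitrogen; no ring) in place of a group of 8 heavy atoms (4 carbon, 4 nitrogen; no ring), on a saturated chain carbon, three bonds along the chain from an aromatic nitrogen; this is the same kind of change as that from compound 1 to compound 2, but the place differs, three bonds along the chain from an aromatic nitrogen rather than four. As the measured step of this kind is unreadable, the expectation rests on compound 3 alone with its value of 60.8 mg/kg. Compound 4 is expected to give 75 mg/kg, from 30 mg/kg to 180 mg/kg, a step of a 1.2-fold higher number from compound 3 to compound 4 (0.09 log units; within the scatter) that is estimated to stay within the usual scatter.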

Compound 4, dose for half-maximal effect: > 100 mg/kg
Compound 4: a limit, no number; the forecaster's own chance of this, stated with the estimate: 35%; middle value at least 1.3-fold (0.12 log units) away from the limit.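

On the core of compound 3, the group of 7 heavy atoms in place of the group of 8 heavy atoms gives an at least 1.6-fold higher number from compound 3 to compound 4 (0.21 log units; that floor lies within the scatter), so this floor does not by itself establish a real loss in this assay. The value of compound 4 is a limit of the assay and not a number, and the same limit is shared by most of the compounds shown: the limit of > 100 mg/kg in this assay, at which 3 of the 4 values shown sit. The same change on the core of compound 1 cannot be read, so nothing shows whether it carries from one core to the other, or whether its size would match.

As far as these compounds go, it remains open how an amine or a carboxylic acid in place of the group of 8 heavy atoms would read in this assay. From the compounds shown here alone, a longer chain on the core of compound 3 also remains open.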